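A few compounds are considered here, and "the series" means these few. Any claim that something is new, unique, unknown or untested is made for them only; others in the source may bear on it.

Measured so far:
- compound 1 `CCNC(=O)N1CCN(C(=S)SCc2cn(Cc3ccccc3F)nn2)CC1`: 2830 nM
- compound 2 `CCNC(=O)N1CCN(C(=S)SCc2cn(Cc3cc(OC)c(OC)c(OC)c3)nn2)CC1`: 101000 nM

In a functional assay on MGC-803 cells (Homo sapiens) for cytotoxicity, read by MTT assay, with a stated time of 72 h (on this read-out lower numbers stand for stronger inhibition and higher numbers for weaker inhibition), compound 1 gives 2830 nM, while compound 2 gives 101000 nM, the highest of the two numbers, with the gap between them beyond the scatter. Within the data shown here, no pair that differs in one place has been measured, so no step on the shared core is known.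

Compound 3 `CCN(C)C(=O)N1CCN(C(=S)SCc2cn(Cc3cc(OC)c(OC)c(OC)c3)nn2)CC1` differs from compound 2 by methyl in place of hydrogen on an amide-type nitrogen, read one bond further out as ethylcarbamoyl to ethyl(methyl)carbamoyl. Among the measured compounds shown here, the data hold no precedent for such a change on this core, so the direction of the step is open. The expected step from compound 2 to compound 3 in this assay, a 1.0-fold lower number from compound 2 to compound 3 (0.00 log units; within the scatter), is none beyond the scatter. Compound 3 is estimated at 100000 nM, with a range of 30000 nM to 300000 nM.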

Compound 3, half-maximal inhibitory concentration: 85700 nM
Beside the measured number, compound 3's estimate is 1.2-fold (0.07 log units) above it, within the range that was stated.
By their numbers in this assay, from the lowest: compound 1; then compounds 3 and 2 (each within the scatter of the next).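

In this assay the series now has its first step on the shared core: methyl in place of hydrogen on the amide-type nitrogen gives a 1.2-fold lower number from compound 2 to compound 3 (0.07 log units; within the scatter) and leaves the read-out within the scatter. On the core of compound 2, the amide hydrogen at this position is therefore not required to keep the number where it stands, and ethylcarbamoyl and ethyl(methyl)carbamoyl cannot be told apart here. This holds for a single change on a single core and sets no trend for the position.

Open, going by these compounds, is whether the same methyl change holds on the core of compound 1, and whether a longer chain such as propyl, or a chain carrying an amine, on this nitrogen would move the number. No measurement on hand offers an explanation for this step.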